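Difluorophenyl to dimethylthiazole on the amide nitrogen

This account rests on a few compounds, and the source may have more. Where it says the series, first, only, none or still open, it means among the compounds named here.

Compound 3 `COc1ccc2nc(C)cc(OCC(=O)Nc3cc(F)cc(F)c3)c2c1` belongs to a small set of amides built on one shared core. In a toxicity assay on HepG2 cells (Homo sapiens) for inhibition, read by CellTiter-Glo, with a stated time of 48 h (a lower number here means a stronger inhibitor, a higher number a weaker inhibitor), compound 3 gives only a limit, > 100000 nM, and no number. It therefore sits at the limit of > 100000 nM in this assay, at which 1 of the 3 values shown sits. Its neighbours give numbers: compound 1 `COc1ccc2c(OCC(=O)Nc3cc(C)cc(C)c3)cc(C)nc2c1` gives 50100 nM in this assay, and compound 2 `COc1ccc2nc(C)cc(OCC(=O)Nc3cc(C)c(OC)c(C)c3)c2c1` gives 7940 nM in this assay. Compound 4 `COc1ccc2nc(C)cc(OCC(=O)Nc3nc(C)c(C)s3)c2c1` is not yet measured. It differs from compound 3 by 4,5-dimethyl-1,3-thiazol-2-yl in place of 3,5-difluorophenyl on an amide-type nitrogen. Because compound 3 sits at the limit of > 100000 nM in this assay, at which 1 of the 3 values shown sits, a step from it can only move toward a stronger inhibitor or stay at the limit. The expected step, an at least 2.5-fold lower number from compound 3 to compound 4 (0.39 log units; beyond the scatter), is a modest move toward stronger inhibition, though another limit would not surprise. Compound 4 is expected at 40000 nM in this assay, within 8000 nM to 150000 nM.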

Compound 4, half-maximal inhibitory concentration: > 100000 nM
Compound 4: only a limit was reported (the forecaster's own chance of this, stated with the estimate: 35%); at least 2.5-fold (0.39 log units) between middle value and limit.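

Among these compounds, compound 3 and compound 4 both give only a limit, so no step between them can be read: the limit of > 100000 nM in this assay, at which 2 of the 4 values shown sit. The compounds shown leave open whether 4,5-dimethyl-1,3-thiazol-2-yl in place of 3,5-difluorophenyl changes inhibition at all.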